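The compounds below may be only part of what the source reports. "The series", "measured", "known", "first", "only" and "open" are said of these compounds alone.

Measured in an ADME assay on Vero cells (Chlorocebus sabaeus) for inhibition, read by CellTiter-Glo, with a stated time of 2 days; a higher number here means a weaker inhibitor, a lower number a stronger inhibitor (each value is a limit, not a number):
Compound 1 (`NC(=O)c1sc(N2CCCCC2)cc1OCCc1ccccc1`): > 100000 nM (a limit)
Compound 2 (`NC(=O)c1sc(-n2nccn2)cc1OCCc1ccccc1`): > 100000 nM (a limit)

Compound 2 has no numerical value in this assay, only its limit of > 100000 nM. Going by the values given here, the one other value available is also a limit. Compound 3 (`NC(=O)c1sc(-c2ccncc2)cc1OCCc1ccccc1`) carries pyridin-4-yl in place of 2H-1,2,3-triazol-2-yl on an aromatic carbon, next to the ring sulfur: pyridin-4-yl in place of 2H-1,2,3-triazol-2-yl on an aromatic carbon.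

Among the compounds with values here, the only measured step bearing on this change is a step that the two limits leave unreadable from compound 1 to compound 2, and it gives no size to carry over. What remains is the limit of > 100000 nM in this assay, at which 2 of the 2 values shown sit. On that basis, no step beyond the scatter is expected, and another limit reading is the likeliest outcome. For compound 3 the estimated value is 100000 nM, with an expected range from 40000 nM to 200000 nM. This estimate means an expected a number no higher from compound 2 to compound 3 (the limit leaves the size open).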

Compound 3, half-maximal inhibitory concentration: 5900 nM
For compound 3 the middle estimate is 17-fold (1.23 log units) above the measured one, outside the stated range (below it).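

In this assay, going by these compounds alone, compound 3 is the only one of the three compounds to give a number rather than a limit, so the substituent on this aromatic carbon, next to the ring sulfur, can move the reading: the limit of > 100000 nM in this assay, at which 2 of the 3 values shown sit. Pyridin-4-yl in place of 2H-1,2,3-triazol-2-yl gives an at least 16-fold lower number from compound 2 to compound 3 (1.22 log units; beyond the scatter), and pyridin-4-yl in place of piperidin-1-yl gives an at least 16-fold lower number from compound 1 to compound 3 (1.22 log units; beyond the scatter). Within the data shown here, the earlier step between compound 1 and compound 2 cannot be read, so these two steps are the first readable changes at this position.

The compounds shown leave open whether the reading depends on the presence of the pyridine nitrogen or on where it sits, as a plain phenyl or a pyridin-3-yl group on this carbon would tell. They also leave open how the carbamoyl group, unchanged across all three, bears on the reading.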